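The compounds below may be only part of what the source reports. "The series", "measured", "known", "first", "only" and "open" are said of these compounds alone.

Three compounds share one core and differ only in the substituent on the phenyl ring. Compound 1 `Clc1ccc(-c2nc3ncccc3o2)cc1` carries a chloro group and, in a functional assay on the whole organism for inhibition, with Rattus norvegicus as the target, at a dose of 30 mg/kg (a higher number here means more inhibition at the dose given (going by the name of the read-out), a lower number less inhibition), gives 24%. Compound 3 `c1ccc(-c2nc3ncccc3o2)cc1` carries no substituent there, and in this assay compound 3 gives 41%. Compound 2 `COc1cccc(-c2nc3cccnc3o2)c1` carries a methoxy group, and in this assay compound 2 gives 0%, the lowest of the three numbers: compound 1 stands above it beyond the scatter, and compound 3 stands further above it, also beyond the scatter.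

Compound 4 `Clc1cccc(-c2nc3cccnc3o2)c1` is reached from compound 2 by chloro in place of methoxy on an aromatic carbon. Going by the values given here, no measured step exchanges methoxy for chloro. Among the compounds with values here, the one step that touches a chloro group is a number 17 percentage points higher from compound 1 to compound 3 (beyond the scatter), a modest rise when chloro is removed, but at another place on the ring, so its bearing on this change is indirect. With compound 2 at the bottom and chloro having looked somewhat unfavourable against hydrogen in that step, a modest rise from the floor is expected rather than a large one. The estimate for compound 4 in this assay is 15%, within 0% to 35%. That expectation corresponds to a step of a number 15 percentage points higher from compound 2 to compound 4 (beyond the scatter).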

Compound 4, a percentage reported as inhibition, in the whole organism at one dose (the size of the read-out at that dose, not a potency): 8%
Compound 4: the middle estimate sits 7 percentage points above what was measured, and the stated range covers the measured number.
By their numbers in this assay, from the lowest: compounds 2 and 4 (each within the scatter of the next); then compound 1; then compound 3.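

In this assay, the exchange at this position amounts to a number 8 percentage points higher from compound 2 to compound 4 (within the scatter), so chloro in place of methoxy on this aromatic carbon, meta to a group of 9 heavy atoms, does not separate the two compounds. Going by these compounds alone, this is the first measured step at this place, and it shows that replacing two heavy atoms and a hydrogen-bond acceptor with one heavy atom and no acceptor leaves the number within the scatter. Nothing measured here bears on why these two groups read alike.

The compounds shown leave open whether an amine, a carboxylic acid or a longer chain at this same place would move the number beyond the scatter. Within the data shown here, they also leave open how hydrogen at this place would compare, since no step links it to compound 4.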